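Sulfonate esters with a chloropropylurea: swapping the phenyl group

The source may report more compounds than this note shows. Statements on the series, on what has been measured and on what is new or still open speak of the compounds shown alone.

Measured so far:
- compound 1, `Cc1ccccc1OS(=O)(=O)c1cccc(NC(=O)NCCCCl)c1`: 29000 nM
- compound 2, `CCc1ccccc1OS(=O)(=O)c1cccc(NC(=O)NCCCCl)c1`: 24000 nM
- compound 3, `CCCc1ccccc1OS(=O)(=O)c1cccc(NC(=O)NCCCCl)c1`: 15000 nM

All three compounds were tested in a functional assay on M21 cells (Homo sapiens) for cytotoxicity, read by sulforhodamine B assay, with a stated time of 48 h; a higher number here means a weaker inhibitor, a lower number a stronger inhibitor. Compound 3 gives the lowest number of the three, but the steps toward it are a 1.6-fold lower number from compound 2 to compound 3 (0.20 log units; within the scatter) and a 1.9-fold lower number from compound 1 to compound 3 (0.29 log units; within the scatter), so the three values sit together and no one of them can be called stronger or weaker than the others.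

Compound 4, `O=C(NCCCCl)Nc1cccc(S(=O)(=O)Oc2ccc(O)cc2)c1`, differs from compound 3 in one place: 4-hydroxyphenyl in place of 2-propylphenyl on an oxygen. The steps seen so far, a 1.2-fold lower number from compound 1 to compound 2 (0.08 log units; within the scatter) and a 1.9-fold lower number from compound 1 to compound 3 (0.29 log units; within the scatter), only lengthen the chain on the phenyl ring, and none of them removes that chain or brings in a hydroxyl. They therefore bear only loosely on this change; what they show is that the chain has not moved the number beyond the scatter in either direction.

For compound 4 the expected step is a 1.9-fold higher number from compound 3 to compound 4 (0.27 log units; within the scatter), a small move back toward the numbers of compound 1 and compound 2, with nothing beyond the scatter expected. The estimate for compound 4 is 28000 nM, with a range from 10000 nM to 80000 nM.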

Compound 4, half-maximal inhibitory concentration: 49000 nM
Compound 4: the middle estimate sits 1.8-fold (0.24 log units) below what was measured; measured number inside the range.
By their numbers in this assay, from the lowest: compounds 3, 2, 1 and 4 (each within the scatter of the next, the first and the last beyond it).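

In this assay, for the compounds shown here, the change on the oxygen bound to the sulfonyl sulfur produces the first steps in this set that lie beyond the scatter, with 4-hydroxyphenyl in place of 2-propylphenyl giving a 3.3-fold higher number from compound 3 to compound 4 (0.51 log units; beyond the scatter) and in place of 2-ethylphenyl giving a 2.0-fold higher number from compound 2 to compound 4 (0.31 log units; beyond the scatter). These steps are modest, and the comparison with the shortest chain gives a 1.7-fold higher number from compound 1 to compound 4 (0.23 log units; within the scatter), so compound 4 cannot be separated from compound 1, and the result depends on which chain it is compared with. Since this one change removes the chain, brings in a hydroxyl and moves the group's place on the ring all at once, the step cannot be assigned to any one of these, and no measurement here offers an explanation for it.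

From the compounds shown here alone, it remains open whether losing the chain or gaining the hydroxyl carries the step, a question that plain phenyl and 4-propylphenyl on the same oxygen could help to separate. Going by these compounds, it is also open whether 4-methoxyphenyl or 4-aminophenyl would give numbers closer to compound 3 or to compound 4.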